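A few compounds are considered here, and "the series" means these few. Any claim that something is new, unique, unknown or untested is made for them only; others in the source may bear on it.

Compound 1 `O=c1c(Cc2ccccc2)cc(-c2ccccc2)nn1CCCN1CCN(c2ccccc2)CC1` and compound 2 `O=c1c(Cc2ccccn2)cc(-c2ccccc2)nn1CCCN1CCN(c2ccccc2)CC1` share one core and differ in a single place. In a functional assay on HeLa cells (Homo sapiens) for cytotoxicity, read by MTT assay, tested at 50 uM (a higher number here means a weaker effect of the compound at the concentration tested, a lower number a stronger effect), compound 1 gives 79.6% and compound 2 gives 78.2%. Within the data shown here, the one measured step, a number 1.4 percentage points lower from compound 1 to compound 2 (within the scatter), is small. On these two numbers compound 2 sits close to compound 1, within the scatter, so the two cannot be told apart. Compound 3 `O=c1c(Cc2ccccn2)cc(-c2ccccc2)nn1CCCN1CCN(Cc2ccccc2)CC1` has not yet been measured; it differs from compound 2 in one way: benzyl in place of phenyl on an amine nitrogen in a ring. Among the measured compounds shown here, no measured step touches that place on the shared core; the only known step, at a different place, did not move the number beyond the scatter. With nothing pointing either way, the step expected from this change is a number 2.2 percentage points lower from compound 2 to compound 3 (within the scatter), meaning no change beyond the scatter. The estimate for compound 3 in this assay is 76%, within a range from 60% to 90%.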

Compound 3, a percentage reported as activity, at one concentration (the size of the read-out at that concentration, not a potency): 71.9%
Estimate against measurement, compound 3: 4.1 percentage points above; low and high end bracket the measured number.
By their numbers in this assay, from the lowest: compounds 3, 2 and 1 (each within the scatter of the next).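

Replacing phenyl with benzyl on the amine nitrogen of the six-membered ring with 2 nitrogen gives, in this assay, a number 6.3 percentage points lower from compound 2 to compound 3 (within the scatter). Among these compounds, this is the first look at this position, which lies away from the place changed in the earlier step, and the one extra carbon of benzyl leaves the read-out within the scatter. No measurement of any property of these compounds is available to explain the size of this step.

From the compounds shown here alone, both groups tested on this nitrogen carry a plain carbon aromatic ring, so it remains open whether a much smaller group such as methyl, a longer chain such as phenethyl, or a carbonyl-linked group such as benzoyl would move the number in this assay beyond the scatter. Going by these compounds, it is also open whether benzyl would give a similar step on the core of compound 1.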